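Epimer of a lipopeptide agonist at the glycerol-type carbon

A few compounds are considered here, and "the series" means these few. Any claim that something is new, unique, unknown or untested is made for them only; others in the source may bear on it.

Measured compounds:
compound 1 `CCCCCCCCCCCCCCCC(=O)OC[C@@H](CSC[C@H](NC(=O)OC(C)(C)C)C(=O)N[C@@H](COC(C)(C)C)C(=O)OC)OC(=O)CCCCCCCCCCCCCCC`: 4270 nM
compound 2 `CCCCCCCCCCCCCCCC(=O)OC[C@@H](CSC[C@H](NC(C)=O)C(=O)N[C@@H](CO)C(=O)OC)OC(=O)CCCCCCCCCCCCCCC`: 252 nM

In an assay on HEK-Blue hTLR2-TLR6 cells for agonist activity at TLR2/TLR6 (Homo sapiens), read by reporter gene assay (on this read-out lower numbers stand for an effect already at smaller amounts and higher numbers for an effect only at larger amounts of compound), compound 1 gives the higher of the two numbers; compound 2, with 252 nM, stands well apart from it, beyond the scatter. Compound 3 `CCCCCCCCCCCCCCCC(=O)OC[C@H](CSC[C@H](NC(=O)OC(C)(C)C)C(=O)N[C@@H](COC(C)(C)C)C(=O)OC)OC(=O)CCCCCCCCCCCCCCC` is the unmeasured partner of compound 1: the two compounds have the same atoms and bonds and differ only in configuration as drawn: 1 of 3 stereo elements differ; a stereocentre at a saturated chain carbon is drawn S in compound 1 and R in compound 3. Among the compounds with values here, no measured pair shows the effect of such a change in configuration alone, so the size of the step in this assay is uncertain; a step of moderate size, in either direction, is expected, given as a 1.7-fold lower number from compound 1 to compound 3 (0.23 log units; within the scatter). For compound 3 the expected value is 2500 nM, within a range of 500 nM to 12000 nM.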

Compound 3, half-maximal effective concentration: 5870 nM
Estimate against measurement, compound 3: 2.3-fold (0.37 log units) below, within the range that was stated.
By their numbers in this assay, from the lowest: compound 2; then compounds 1 and 3 (each within the scatter of the next).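

In this assay, the switch at the saturated chain carbon from S to R gives a 1.4-fold higher number from compound 1 to compound 3 (0.14 log units; within the scatter), so the two compounds stand level within the scatter. With the other groups of compound 1 in place, the configuration drawn at this carbon therefore shows no measurable effect on this read-out. The comparison is a clean one, and it rests on a single point: the fact that compounds 1 and 3 differ only in the configuration as drawn

From the compounds shown here alone, it remains open whether this carbon matters as little on the core of compound 2, which carries an acetyl group and a free hydroxyl. Also open, going by these compounds, is whether the same holds with a free amine or with a carboxylic acid in place of the methyl ester.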